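Cyclopropylamino in Place of Methoxy(methyl)amino on the Amide Carbonyl

A few compounds are considered here, and "the series" means these few. Any claim that something is new, unique, unknown or untested is made for them only; others in the source may bear on it.

The measured compounds and their values:
- compound 1, `CCNC(=O)/C=C1\CCc2ccc(F)cc21`: 63%
- compound 2, `O=C(/C=C1\CCc2ccc(F)cc21)NC1CCC1`: 0%
- compound 3, `CON(C)C(=O)/C=C1\CCc2ccc(F)cc21`: 14%

All three share one core and differ only in the group attached to the carbonyl carbon. In a functional assay on the whole organism with Rattus norvegicus as the target, at a dose of 20 mg/kg by the oral route (a lower number here means less inhibition, a higher number more inhibition at the dose given (going by the name of the read-out)), compound 1 gives 63%, compound 2 gives 0% and compound 3 gives 14%. Compound 3 therefore stands second highest of the three; its nearest neighbour is compound 2, its furthest compound 1. The two steps that lead to it are large in one case, a number 49 percentage points lower from compound 1 to compound 3 (beyond the scatter), and modest in the other, a number 14 percentage points higher from compound 2 to compound 3 (beyond the scatter).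

Compound 4, `O=C(/C=C1\CCc2ccc(F)cc21)NC1CC1`, has not yet been measured in this assay. The change from compound 3 is cyclopropylamino in place of methoxy(methyl)amino on a carbonyl carbon: the group that leaves carries one hydrogen-bond acceptor and no ring, the group that enters carries one hydrogen-bond donor and a three-membered ring of carbon only.

For the measured compounds named here, two measured steps bear on this. The step of a number 63 percentage points lower from compound 1 to compound 2 (beyond the scatter) shows that a four-membered ring on the amide nitrogen, in place of ethyl, removed the inhibition altogether, and the step of a number 14 percentage points higher from compound 2 to compound 3 (beyond the scatter) shows that methoxy(methyl)amino sits somewhat above that ring. Cyclopropylamino has not been tested here, and the three compounds do not fix where it will fall; the entering ring is smaller than the one in compound 2, and the ethyl of compound 1 is the closest measured group that carries a hydrogen-bond donor. The expected step is therefore upward but uncertain, a number 11 percentage points higher from compound 3 to compound 4 (beyond the scatter), and it may well fall within the scatter. For compound 4 an inhibition of 25% is estimated, within a range from 0% to 60%.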

Compound 4, a percentage reported as inhibition, in the whole organism at one dose (the size of the read-out at that dose, not a potency): 7%
Compound 4: middle estimate off by 18 percentage points, on the high side; measured number inside the range.
By their numbers in this assay, from the lowest: compounds 2, 4 and 3 (each within the scatter of the next, the first and the last beyond it); then compound 1.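

In this assay, the step is a number 7 percentage points lower from compound 3 to compound 4 (within the scatter), so putting cyclopropylamino on the carbonyl carbon, with its hydrogen-bond donor and three-membered ring, does not separate compound 4 from the methoxy(methyl)amino group that carries a hydrogen-bond acceptor and no ring. The ring size on the amide nitrogen is not resolved either, since the step is a number 7 percentage points higher from compound 2 to compound 4 (within the scatter), and the three-membered and four-membered rings cannot be told apart in this assay. The step of a number 56 percentage points lower from compound 1 to compound 4 (beyond the scatter) shows that the large loss seen earlier with cyclobutyl in place of ethyl is not confined to that one ring, as it recurs with cyclopropyl, so among compounds 1, 2 and 4 only the open ethyl chain keeps a high number.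

Nothing at hand accounts for the gap between the ethyl group and the two rings. On these data alone, it remains open whether the high number belongs to ethyl alone or extends to other open chains on the amide nitrogen, such as methyl, n-propyl or isopropyl.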